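A few compounds are considered here, and "the series" means these few. Any claim that something is new, unique, unknown or untested is made for them only; others in the source may bear on it.

Compound 1, `Cc1cc(-c2ccco2)c(S(C)(=O)=O)cc1C(=O)N=C(N)N`, gives 16 nM in a functional assay for inhibition of sodium/hydrogen exchanger (Oryctolagus cuniculus); on this read-out lower numbers stand for stronger inhibition and higher numbers for weaker inhibition.
Compound 2, `Cc1cc(OC2CCCCC2)c(S(C)(=O)=O)cc1C(=O)N=C(N)N`, gives 37 nM in this assay.

Compound 2 stands at the highest of the two numbers in this assay; its nearest neighbour is compound 1, and the step runs a 2.3-fold higher number from compound 1 to compound 2 (0.36 log units; beyond the scatter). Compound 3, `Cc1cc(C(F)(F)F)c(S(C)(=O)=O)cc1C(=O)N=C(N)N`, differs from compound 2 in one place: trifluoromethyl in place of cyclohexyloxy on an aromatic carbon. Within the data shown here, the only measured step, a 2.3-fold higher number from compound 1 to compound 2 (0.36 log units; beyond the scatter), exchanges one ring-bearing group for another at this same aromatic carbon and was modest. Among the measured compounds shown here, no measured pair replaces a ring-bearing group with trifluoromethyl, so that step bears on the new change only loosely and leaves the direction open. For the measured compounds named here, since the one change seen at this position moved the number only by a 2.3-fold higher number from compound 1 to compound 2 (0.36 log units; beyond the scatter), compound 3 is expected to stay close to the measured pair, with a wide range. Compound 3 is estimated at 40 nM, between 12 nM and 150 nM. The expected step is a 1.1-fold higher number from compound 2 to compound 3 (0.03 log units; within the scatter), not beyond the scatter.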

Compound 3, half-maximal inhibitory concentration: 37 nM
Compound 3: the middle estimate sits 1.1-fold (0.03 log units) above what was measured, within the range that was stated.
By their numbers in this assay, from the lowest: compound 1; then compounds 2 and 3 (each within the scatter of the next).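

In this assay the change from cyclohexyloxy to trifluoromethyl gives no change at the digits printed from compound 2 to compound 3 (within the scatter) and so this aromatic carbon, ortho to the methylsulfonyl group, accepts a group with no ring as well as one with a six-membered non-aromatic ring, with no difference in the read-out. Measured against the furan-2-yl group, trifluoromethyl gives a 2.3-fold higher number from compound 1 to compound 3 (0.36 log units; beyond the scatter) and cyclohexyloxy gives a 2.3-fold higher number from compound 1 to compound 2 (0.36 log units; beyond the scatter) so compound 1 stands apart from both compound 2 and compound 3, and a ring as such does not separate these groups. The data shown offer no measurement that explains these readings.

The compounds shown leave open how an amine, a carboxylic acid or a longer alkoxy chain would read at this aromatic carbon. They also leave open whether an aromatic ring other than furan-2-yl, such as phenyl or thiophene, would match compound 1.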